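Sulfonyl substituent change in the aortic maximal-response series

The source may report more compounds than this note shows. Statements on the series, on what has been measured and on what is new or still open speak of the compounds shown alone.

The shared core appears in compound 1 `CC1(C)C=C(n2ccccc2=O)c2cc(S(=O)(=O)NCCO)ccc2O1` and in compound 2 `CC1(C)C=C(n2ccccc2=O)c2cc(S(=O)(=O)N3CCOCC3)ccc2O1`. In a functional assay on the whole organism (aorta) with Rattus norvegicus as the target (a lower number here means a smaller maximal response, a higher number a larger maximal response), compound 1 gives 95.5%, and compound 2 gives 75.5%. For the measured compounds named here, the only step measured so far runs a number 20 percentage points lower from compound 1 to compound 2 (beyond the scatter). Among the two numbers available compound 2 stands lowest, with compound 1 as its nearest neighbour.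

Compound 3 `CC1(C)C=C(n2ccccc2=O)c2cc(S(=O)(=O)c3ccccc3)ccc2O1` differs from compound 2 by phenyl in place of morpholin-4-yl on a sulfonyl sulfur. Going by the values given here, no measured step covers an aromatic group on the sulfonyl sulfur. Among the compounds with values here, the single step that touches this position, a number 20 percentage points lower from compound 1 to compound 2 (beyond the scatter), shows that exchanging the group there shifted the maximal response by a modest amount beyond the scatter, so a change of comparable size is plausible here as well; the direction, however, is not indicated by anything measured. The step expected for this exchange, a number 4.5 percentage points higher from compound 2 to compound 3 (within the scatter), is therefore placed close to zero with a broad range. Compound 3 is estimated at 80%, with a range from 60% to 100%.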

Compound 3, largest response reached (Emax), in percent of the reference or control that the assay uses: 79.3%
Beside the measured number, compound 3's estimate is 0.7 percentage points above it; the measured number falls inside the stated range.
By their numbers in this assay, from the lowest: compounds 2 and 3 (each within the scatter of the next); then compound 1.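

At the sulfonyl sulfur, this assay gives a number 3.8 percentage points higher from compound 2 to compound 3 (within the scatter), so morpholin-4-yl, a six-membered non-aromatic ring with 2 hetero atoms, and phenyl, a six-membered aromatic ring of carbon only, are not separated in these notes. The step of a number 16.2 percentage points lower from compound 1 to compound 3 (beyond the scatter) points the same way as a number 20 percentage points lower from compound 1 to compound 2 (beyond the scatter), which sets (2-hydroxyethyl)amino apart from both ring groups among these three compounds, and none of the three goes against this. No supporting measurement bears on why the maximal response differs in this way.

As far as these compounds go, it remains open whether the difference of compound 1 from the two ring groups belongs to the terminal hydroxyl or to the amino link of (2-hydroxyethyl)amino; ethylamino, dimethylamino or a longer 3-hydroxypropylamino chain on the sulfonyl sulfur would help to separate these. Also open, from the compounds shown here alone, is how far the match between compound 2 and compound 3 extends to other groups at this place, such as piperidin-1-yl, pyridinyl or a small methyl.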